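Amide Substituent Changes in a Shared Core Series

A few compounds are considered here, and "the series" means these few. Any claim that something is new, unique, unknown or untested is made for them only; others in the source may bear on it.

Measured compounds:
compound 1 `Cc1noc(C)c1-c1cnc(N)c(Oc2ccc(C(=O)NC3CCCC3)cc2)n1` — 12800 nM
compound 2 `Cc1noc(C)c1-c1cnc(N)c(Oc2ccc(C(=O)Nc3ccccc3)cc2)n1` — 11800 nM
compound 3 `Cc1noc(C)c1-c1cnc(N)c(Oc2ccc(C(=O)Nc3ccc(Cl)cn3)cc2)n1` — 35600 nM

In a functional assay on HepG2 cells (Homo sapiens) for inhibition, read by MTT assay, with a stated time of 72 h (on this read-out lower numbers stand for stronger inhibition and higher numbers for weaker inhibition), compound 1 stands second highest of the three numbers; compound 2 sits within the scatter of it, while compound 3 lies beyond. Compound 4 `Cc1noc(C)c1-c1cnc(N)c(Oc2ccc(C(=O)Nc3ncccc3Cl)cc2)n1` differs from compound 1 by 3-chloropyridin-2-yl in place of cyclopentyl on an amide-type nitrogen. Among the compounds with values here, two measured steps bear on this: a 1.1-fold lower number from compound 1 to compound 2 (0.04 log units; within the scatter), and a 2.8-fold higher number from compound 1 to compound 3 (0.44 log units; beyond the scatter); the latter, a related chloropyridinyl group, is the closer guide. Compound 4 is therefore expected to show a modest rise, a 2.0-fold higher number from compound 1 to compound 4 (0.31 log units; beyond the scatter), with no pattern claimed beyond these compounds. The estimate for compound 4 in this assay is 26000 nM, with a range from 11000 nM to 60000 nM.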

Compound 4, half-maximal inhibitory concentration: 27200 nM
The estimate for compound 4 lay 1.0-fold (0.02 log units) below the measured number, within the range that was stated.
By their numbers in this assay, from the lowest: compounds 2 and 1 (each within the scatter of the next); then compounds 4 and 3 (each within the scatter of the next).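

In this assay, 3-chloropyridin-2-yl on the amide-type nitrogen gives a 2.1-fold higher number from compound 1 to compound 4 (0.33 log units; beyond the scatter) and a 2.3-fold higher number from compound 2 to compound 4 (0.36 log units; beyond the scatter), so a second chloropyridinyl group now stands apart from both the cyclopentyl and the phenyl compound. Putting 3-chloropyridin-2-yl in place of 5-chloropyridin-2-yl gives a 1.3-fold lower number from compound 3 to compound 4 (0.12 log units; within the scatter), so these two chloropyridinyl groups cannot be told apart here. No available evidence gives a cause for these steps. The compounds shown leave open whether the chlorine or the ring nitrogen accounts for the rise, which a plain pyridin-2-yl group or a 3-chlorophenyl group on that nitrogen could separate.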